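Chloro for Methoxy: Estimating an Untested Channel Agonist

This account rests on a few compounds, and the source may have more. Where it says the series, first, only, none or still open, it means among the compounds named here.

Among the measured compounds shown here, compound 2, `CCN(Cc1cccs1)C(=O)COc1ccc(OC)cc1`, is the only compound in this small set with a number to its name. In an assay on HEK293 cells for agonist activity at transient receptor potential cation channel subfamily M member 8 (Homo sapiens), read by fluorescence and calcium flux, with a stated time of 15 min (on this read-out lower numbers stand for an effect already at smaller amounts and higher numbers for an effect only at larger amounts of compound), compound 2 gives 120 nM. Compound 1, `CCN(Cc1cccs1)C(=O)COc1ccc(C(=O)O)cc1`, is reported in this assay as "not active" (no number reported), so no number exists for it. For the measured compounds named here, with a single number and one entry without a number, no step between two measured compounds can be drawn.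

Compound 3, `CCN(Cc1cccs1)C(=O)COc1ccc(Cl)cc1`, has not yet been measured. It differs from compound 2 in one place: chloro in place of methoxy on an aromatic carbon. Going by the values given here, nothing among the measured compounds shows how this particular swap plays out; the only other compound, compound 1, offers no number to compare against. With so little to lean on, the expectation for compound 3 is that it stays near compound 2, and the step of a 1.3-fold higher number from compound 2 to compound 3 (0.10 log units; within the scatter) is expected to remain within the usual scatter of repeated measurements. The estimate for compound 3 in this assay is therefore 150 nM, with a range from 40 nM to 600 nM.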

Compound 3, half-maximal effective concentration: 39 nM
Estimate against measurement, compound 3: 3.8-fold (0.59 log units) above, and the stated range ends above it.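

Chloro in place of methoxy on an aromatic carbon, para to a large group, is not a neutral swap in this assay: it gives a 3.1-fold lower number from compound 2 to compound 3 (0.49 log units; beyond the scatter), a modest step but one that lies beyond the scatter. Among the compounds shown here, this is the first number-to-number comparison at this position, and it shows that the read-out responds to what sits there and that the methoxy group is not needed for an effect at this level, since a single chlorine atom in its place gives the lower number of the two. This rests on one pair of compounds, and no measurement at hand bears on what lies behind the step.

As far as these compounds go, whether the lower number is particular to chloro stays open, and compounds with fluoro, bromo, methyl or trifluoromethyl on this same aromatic carbon would help to show whether chlorine is special or just one of several groups that work here. From the compounds shown here alone, it is also open whether the swap from methoxy to chloro would give a similar step on a related compound, for example one that carries a longer chain elsewhere on the shared core.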